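A few compounds are considered here, and "the series" means these few. Any claim that something is new, unique, unknown or untested is made for them only; others in the source may bear on it.

Three compounds built on a shared core have been run through an ADME assay on microsomes from liver (Mus musculus) for metabolic stability; a lower number here means slower removal, a higher number faster removal of the compound. Compound 1 `NC(=O)CNC(=O)C[C@@H]1CCC[C@]2(C1)OOC1(O2)C2CC3CC(C2)CC1C3` gives 18.6 uL/min. Compound 2 `NCCNC(=O)C[C@@H]1CCC[C@]2(C1)OOC1(O2)C2CC3CC(C2)CC1C3` gives 8.2 uL/min, and compound 3 `CC(C)(CN)CNC(=O)C[C@@H]1CCC[C@]2(C1)OOC1(O2)C2CC3CC(C2)CC1C3` gives 10.8 uL/min. Every difference among them sits on the chain bound to the amide-type nitrogen. Going by the values given here, the only step beyond the scatter is a 2.3-fold lower number from compound 1 to compound 2 (0.36 log units; beyond the scatter). Alongside it, a 1.7-fold lower number from compound 1 to compound 3 (0.24 log units; within the scatter), and a 1.3-fold higher number from compound 2 to compound 3 (0.12 log units; within the scatter). Compound 3 therefore holds the second highest of the three numbers, yet it lies within the scatter of both compound 2 and compound 1, so nothing truly separates it from either.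

Compound 4 `O=C(C[C@@H]1CCC[C@]2(C1)OOC1(O2)C2CC3CC(C2)CC1C3)N1CCNCC1` has not yet been measured. It differs from compound 3 in one place: piperazin-1-yl in place of (2-(aminomethyl)-2-methylpropyl)amino on a carbonyl carbon. Among the compounds with values here, no measured step makes exactly this change; the steps among compounds 1, 2 and 3 swap groups on the chain beyond the amide-type nitrogen and shift the number modestly at most. On that basis the step expected in this assay is a 1.1-fold higher number from compound 3 to compound 4 (0.05 log units; within the scatter), not clearly beyond the scatter. The estimated value for compound 4 is 12 uL/min, with a range from 6 uL/min to 24 uL/min.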

Compound 4, intrinsic clearance in a liver preparation (reported as CLH), per the amount of preparation that the assay uses: 27.2 uL/min
Compound 4: the middle estimate sits 2.3-fold (0.36 log units) below what was measured, outside the stated range (above it).
By their numbers in this assay, from the lowest: compounds 2, 3, 1 and 4 (each within the scatter of the next, the first and the last beyond it).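

Until now every change sat on the chain beyond the amide-type nitrogen, whereas in compound 4 that nitrogen itself becomes part of a ring, the piperazin-1-yl group on the carbonyl carbon. In this assay, going by these compounds alone, this change gives a clear rise against both open chains that end in an amine (a 2.5-fold higher number from compound 3 to compound 4 (0.40 log units; beyond the scatter) and a 3.3-fold higher number from compound 2 to compound 4 (0.52 log units; beyond the scatter)), so this position can respond more strongly than the earlier steps suggested, yet the ring does not stand apart from every open chain, since the (carbamoylmethyl)amino group of compound 1 remains close (a 1.5-fold higher number from compound 1 to compound 4 (0.17 log units; within the scatter)). Nothing available here explains why the number rises with the ring.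

Going by these compounds, it stays open whether the ring itself matters or simply the loss of the hydrogen on the amide-type nitrogen, a question that a (2-aminoethyl)(methyl)amino group, which keeps the open chain but carries a methyl on that nitrogen, could help to settle. On these data alone, it is equally open whether the second ring nitrogen of piperazin-1-yl plays any part, which a morpholin-4-yl or piperidin-1-yl group in its place would test.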